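Chain extension from compound 3 to compound 4: working notes

This account rests on a few compounds, and the source may have more. Where it says the series, first, only, none or still open, it means among the compounds named here.

Measured so far:
Compound 1, `O=C(O)c1cc(=O)c2c(OCCCOc3ccccc3)cccc2o1`, gives 35 ug/mL in a functional assay on ileum (Cavia porcellus) for antagonist activity, with a stated time of 30 s; a higher number here means a weaker inhibitor, a lower number a stronger inhibitor.
Compound 2, `O=C(O)c1cc(=O)c2c(OCCCCCOc3ccccc3)cccc2o1`, gives 17.5 ug/mL in this assay.
Compound 3, `O=C(O)c1cc(=O)c2ccc(OCCCCCCCOc3ccccc3)cc2o1`, gives 1.8 ug/mL in this assay.

Compounds 1 and 2 share a core and differ only by 2-phenoxyethyl in place of phenoxy on a saturated chain carbon, three bonds along the chain from an oxygen on an aromatic ring. That change made the step of a 2.0-fold lower number from compound 1 to compound 2 (0.30 log units; within the scatter), so the two values cannot be ordered. Compound 3 carries a different core; the difference between the two cores of compound 1 and compound 3 is not broken down here. Its number in this assay is the lowest of the three, and its distance from both compound 2 and compound 1 lies beyond the scatter.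

Compound 4, `O=C(O)c1cc(=O)c2ccc(OCCCCCCCCCOc3ccccc3)cc2o1`, is not yet measured. It differs from compound 3 by 2-phenoxyethyl in place of phenoxy on a saturated chain carbon, seven bonds along the chain from an oxygen on an aromatic ring. This is the same kind of change as between compound 1 and compound 2, but not the same: the place is seven bonds along the chain from an oxygen on an aromatic ring here, against three bonds along the chain there. Going by the values given here, the only comparable step is a 2.0-fold lower number from compound 1 to compound 2 (0.30 log units; within the scatter), and no measured pair tests the longer spacing.

On that basis a small step is expected, a 1.5-fold lower number from compound 3 to compound 4 (0.18 log units; within the scatter), because a 2.0-fold lower number from compound 1 to compound 2 (0.30 log units; within the scatter) stayed within the scatter. Compound 4 is therefore estimated at 1.2 ug/mL in this assay, with the likely range from 0.5 ug/mL to 3.5 ug/mL.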

Compound 4, half-maximal inhibitory concentration: 1.8 ug/mL
The estimate for compound 4 lay 1.5-fold (0.18 log units) below the measured number, within the range that was stated.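

In this assay the new step reads no change at the digits printed from compound 3 to compound 4 (within the scatter) and leaves compound 3 and compound 4 unordered, so this change on the core of compound 3 gives no readable shift in the number. Set beside the earlier step, the result on the two cores shows no difference, and so far the change carries from one core to the other as a step too small to read: the same change on two cores in this assay, a 2.0-fold lower number (0.30 log units; within the scatter) from compound 1 to compound 2 and no change at the digits printed (within the scatter) from compound 3 to compound 4, 2.0-fold (0.30 log units) apart, within the scatter of two such steps. Going by these compounds alone, this does not show that the change would behave alike in general, since only two pairs bear on it, both steps stay within the scatter, and the place differs as well as the core, at three bonds along the chain on one and seven on the other.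

The compounds shown leave open how the core alone acts, as no pair here holds the chain fixed while the core changes. Also open, from the compounds shown here alone, is whether a longer chain, an amine or amide within the chain, or a chloro group on the terminal phenoxy ring would give a step beyond the scatter.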